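A few compounds are considered here, and "the series" means these few. Any claim that something is new, unique, unknown or untested is made for them only; others in the source may bear on it.

Measured so far:
Compound 1 `Nc1ccccc1NC(=O)CCCNCC(=O)Nc1cccc(Cl)c1`: > 100000 nM (a limit)
Compound 2 `Nc1ccccc1NC(=O)c1ccc(NCC(=O)Nc2ccc([N+](=O)[O-])cc2)cc1`: 42500 nM
Compound 3 `COc1ccc(NC(=O)CNCCCC(=O)Nc2ccccc2N)cc1`: > 100000 nM (a limit)

For the measured compounds named here, in a functional assay on U-251 cells (Homo sapiens) for inhibition, read by MTT assay, with a stated time of 2 days (on this read-out lower numbers stand for stronger inhibition of growth and higher numbers for weaker inhibition of growth), compound 2 holds the only actual number, 42500 nM. Compound 1 and compound 3 give no number and stand at the limit of > 100000 nM in this assay, at which 2 of the 3 values shown sit. The next compound to be read is compound 4 `Nc1ccccc1NC(=O)c1ccc(NCC(=O)Nc2ccc(Cl)cc2)cc1`, with chloro in place of nitro on an aromatic carbon, para to a large group: chloro in place of nitro on an aromatic carbon.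

Going by the values given here, the only measured step is a step that the two limits leave unreadable from compound 1 to compound 3. Among the compounds with values here, it has no readable size and concerns a different change, so no measured step gauges this replacement. With nothing to set a direction, the expectation rests on compound 2 at 42500 nM, and no shift beyond the scatter is expected in this assay. The expected change is a 1.1-fold lower number from compound 2 to compound 4 (0.03 log units; within the scatter). For compound 4 the estimated value is 40000 nM, with an expected range of 15000 nM to 100000 nM.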

Compound 4, concentration for total growth inhibition: 62500 nM
Compound 4: the middle estimate sits 1.6-fold (0.19 log units) below what was measured; the measured number falls inside the stated range.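

In this assay, chloro in place of nitro on an aromatic carbon, para to a large group, gives a 1.5-fold higher number from compound 2 to compound 4 (0.17 log units; within the scatter). For the compounds shown here, this is the first readable step, and it shows that at this position nitro, with 3 heavy atoms and 2 hydrogen-bond acceptors, can give way to chloro, with 1 heavy atom and no hydrogen-bond acceptors, without a shift beyond the scatter. The earlier pair gave no such reading, since the step between compound 1 and compound 3 cannot be read and both of their values are limits: the limit of > 100000 nM in this assay, at which 2 of the 4 values shown sit.

From the compounds shown here alone, whether an amine or a carboxylic acid on the same aromatic carbon would stay within the scatter of compound 2 remains open. With only nitro and chloro read at this position, no trend across substituents there can be stated.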